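The compounds below may be only part of what the source reports. "The series", "measured", "known", "first", "only" and "open" are said of these compounds alone.

Measured compounds:
Compound 1, `CN1CCN(C(=O)CCCCC(=O)N2CCN(C)CC2)CC1`: 10.9%
Compound 2, `C(CN1CC[N+]2(CCCC2)CC1)CN1CC[N+]2(CCCC2)CC1`: 96%

Both compounds were tested in a functional assay on the whole organism with Mus musculus as the target, in the writhing test, at a dose of 10 mg/kg by the subcutaneous route; a higher number here means more inhibition at the dose given (going by the name of the read-out), a lower number less inhibition. Compound 1 gives 10.9% there, and compound 2 gives 96%. Within the data shown here, of the two numbers, compound 2 stands highest; its only neighbour is compound 1, whose number lies lower by a gap that is beyond the usual scatter. Compound 2 thus already sits close to the ceiling of what this read-out can report.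

Compound 3, `CCOC(CN1CC[N+]2(CCCC2)CC1)CN1CC[N+]2(CCCC2)CC1`, has not yet been measured. It differs from compound 2 in one place: ethoxy in place of hydrogen on a saturated chain carbon bound to two saturated chain carbons. Among the measured compounds shown here, the account can only go by what the two measured compounds show, since no step between them along this kind of change is available. Because compound 2 gives 96%, very little room remains for any increase; the expected step from compound 2 to compound 3 is estimated at a number 11 percentage points lower from compound 2 to compound 3 (beyond the scatter), a small downward movement or none beyond the scatter. Compound 3 is expected to give about 85% in this assay, with a range from 55% to 98%.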

Compound 3, a percentage reported as inhibition, in the whole organism at one dose (the size of the read-out at that dose, not a potency): 46%
Estimate against measurement, compound 3: 39 percentage points above; the measured number lies below the stated range.
By their numbers in this assay, from the lowest: compound 1; then compound 3; then compound 2.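

Among these compounds, the step of a number 50 percentage points lower from compound 2 to compound 3 (beyond the scatter) is the first reading of this position in this assay, and it shows that the saturated chain carbon bound to two saturated chain carbons is not indifferent to what it carries. Ethoxy in place of hydrogen there takes away a large part of the inhibition seen at this dose, yet compound 3 at 46% keeps a clear response, so this change lowers the read-out without removing it. No measurement available here bears on why the number falls.

The compounds shown leave open whether this loss belongs to ethoxy itself or would follow from any group on this carbon, a question that a hydroxyl group, a methoxy group or a longer chain such as butoxy at the same place could help to settle. They also leave open how the response to ethoxy would change with the dose, since each compound is represented here by a single reading at one dose and not by a potency.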